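The source may hold more compounds than are shown below. What is called first, only, known or untested is meant among the compounds shown, and "the series" means these compounds.

Measured so far in a functional assay on DLA cells (Mus musculus) for cytotoxicity, read by LDH release, with a stated time of 48 h; a lower number here means a stronger inhibitor, a higher number a weaker inhibitor:

Compound 1 `Cc1cc(C(=O)c2ccccc2)ccc1OCC(=O)Nc1nc(-c2ccccc2)cs1` gives 23000 nM.
Compound 2 `COc1ccc(-c2csc(NC(=O)COc3ccc(C(=O)c4ccccc4)cc3C)n2)cc1` gives 26200 nM.
Compound 3 `Cc1cc(C(=O)c2cccc(Br)c2)ccc1OCC(=O)Nc1nc(-c2ccccc2)cs1` gives 23600 nM.

Compound 4 `COc1ccc(-c2csc(NC(=O)COc3ccc(C(=O)c4cccc(Br)c4)cc3C)n2)cc1` has not yet been measured in this assay. It differs from compound 3 by methoxy in place of hydrogen on an aromatic carbon. The same change has already been made once among the measured compounds, from compound 1 to compound 2, as methoxy in place of hydrogen on an aromatic carbon, where it gave a 1.1-fold higher number from compound 1 to compound 2 (0.06 log units; within the scatter). The two cores on which the change is made differ by bromo in place of hydrogen on an aromatic carbon, a difference that gave a 1.0-fold higher number from compound 1 to compound 3 (0.01 log units; within the scatter). The place of the change is described in the same words in both pairs, so it is the same change on a slightly different core.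

Since the earlier step of a 1.1-fold higher number from compound 1 to compound 2 (0.06 log units; within the scatter) stayed within the scatter, and the core difference a 1.0-fold higher number from compound 1 to compound 3 (0.01 log units; within the scatter) also did, the step from compound 3 to compound 4 is expected to be similar, about a 1.1-fold higher number from compound 3 to compound 4 (0.05 log units; within the scatter). Compound 4 is therefore estimated at 26500 nM, expected to fall between 15000 nM and 45000 nM.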

Compound 4, half-maximal inhibitory concentration: 37100 nM
Estimate against measurement, compound 4: 1.4-fold (0.15 log units) below, and the stated range covers the measured number.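

In this assay, methoxy in place of hydrogen on an aromatic carbon gives a 1.6-fold higher number from compound 3 to compound 4 (0.20 log units; within the scatter), and bromo in place of hydrogen on an aromatic carbon gives a 1.4-fold higher number from compound 2 to compound 4 (0.15 log units; within the scatter). The methoxy change reads alike on the two cores: the same change on two cores in this assay, a 1.1-fold higher number (0.06 log units; within the scatter) from compound 1 to compound 2 and a 1.6-fold higher number (0.20 log units; within the scatter) from compound 3 to compound 4, 1.4-fold (0.14 log units) apart, within the scatter of two such steps. Going by these compounds alone, the bromo change also reads alike, but since every one of these steps is small, the pairs show only that neither change visibly shifts the number on either core, not that a real effect carries from one core to another: the same change on two cores in this assay, a 1.0-fold higher number (0.01 log units; within the scatter) from compound 1 to compound 3 and a 1.4-fold higher number (0.15 log units; within the scatter) from compound 2 to compound 4, 1.4-fold (0.14 log units) apart, within the scatter of two such steps.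

The compounds shown leave open whether an amine, a carboxylic acid or a longer chain in place of the methoxy would move the number beyond the scatter. They also leave open whether any such step would carry between these cores.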